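Removing a methyl from the amine of compound 3

The compounds below may be only part of what the source reports. "The series", "measured", "known", "first", "only" and "open" are said of these compounds alone.

Three compounds share one core and differ only in the chain hanging from a sulfur. Compound 1, `CC(C)c1n[nH]c2c(NCc3ccc(-c4ccccn4)cc3)nc(SCC(O)CN)nc12`, in a functional assay on HT cells (Homo sapiens) for antiproliferative activity, read by fluorescence, with a stated time of 72 h (on this read-out higher numbers stand for weaker inhibition of growth and lower numbers for stronger inhibition of growth), gives 55 nM. Compound 2, `CCC(O)CSc1nc(NCc2ccc(-c3ccccn3)cc2)c2[nH]nc(C(C)C)c2n1`, gives 273 nM. Compound 3, `CNCCSc1nc(NCc2ccc(-c3ccccn3)cc2)c2[nH]nc(C(C)C)c2n1`, gives 56 nM. Compound 3 has the second highest of the three numbers: its nearest neighbour is compound 1, and the difference a 1.0-fold higher number from compound 1 to compound 3 (0.01 log units; within the scatter) is within the scatter, so the two cannot be told apart; compound 2 sits further off, with a 4.9-fold lower number from compound 2 to compound 3 (0.69 log units; beyond the scatter) separating them.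

Compound 4, `CC(C)c1n[nH]c2c(NCc3ccc(-c4ccccn4)cc3)nc(SCCN)nc12`, is the next step. Relative to compound 3 it carries hydrogen in place of methyl on an amine nitrogen.

Going by the values given here, no measured step tests exactly this change. The closest guide is a 1.0-fold higher number from compound 1 to compound 3 (0.01 log units; within the scatter), where a much larger rearrangement of the chain, including a change at the amine nitrogen, left the number essentially unchanged. Among the compounds with values here, the only step that moved the number beyond the scatter, a 5.0-fold higher number from compound 1 to compound 2 (0.70 log units; beyond the scatter), removed the amine altogether, which is not what happens here. Since compound 4 keeps its amine, the expected step is a 1.0-fold lower number from compound 3 to compound 4 (0.01 log units; within the scatter), one that would fall within the scatter. Compound 4 is therefore estimated at 55 nM, with a likely range from 25 nM to 130 nM.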

Compound 4, concentration for 50% growth inhibition: 22 nM
Compound 4: middle estimate off by 2.5-fold (0.40 log units), on the high side, and the stated range ends above it.
By their numbers in this assay, from the lowest: compound 4; then compounds 1 and 3 (each within the scatter of the next); then compound 2.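

In this assay, going by these compounds alone, the step of a 2.5-fold lower number from compound 3 to compound 4 (0.41 log units; beyond the scatter) is the first to change only the substituent on the amine nitrogen, and it lies beyond the scatter, so a single methyl there matters even though the amine itself stays. The 2-aminoethyl chain of compound 4 also stands apart from the two other chains: the step of a 2.5-fold lower number from compound 1 to compound 4 (0.40 log units; beyond the scatter) is beyond the scatter, and the step of a 12-fold lower number from compound 2 to compound 4 (1.09 log units; beyond the scatter) is the largest in this set, yet the amino group alone does not set the number, since compound 1 also ends in amino and still cannot be told apart from compound 3 with its methylamino end. Nothing measured here explains why these steps have the sizes they do.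

As far as these compounds go, what remains open is whether a larger group on the nitrogen, such as ethyl or a second methyl in a dimethylamino end, would raise the number further than methyl does. A longer chain such as 3-aminopropyl, or a carboxylic acid in place of the amine, would show how much the length of the chain and the amine itself each contribute.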